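This account rests on a few compounds, and the source may have more. Where it says the series, first, only, none or still open, it means among the compounds named here.

For the measured compounds named here, in a functional assay on HEK293 cells for agonist activity at D(4) dopamine receptor (Homo sapiens), read by FLIPR (on this read-out higher numbers stand for larger maximal responses and lower numbers for smaller maximal responses), compound 1 `O=C(CN1CCC(c2cccc[n+]2[O-])CC1)Nc1cccc(Cl)c1` gives 76%, the highest of the three numbers so far. Nearest to it is compound 3 `O=C(CN1CCC(c2cccc[n+]2[O-])CC1)Nc1cccc(-c2ccccc2)c1` with 75%, and furthest is compound 2 `O=C(NCN1CCC(c2cccc[n+]2[O-])CC1)c1ccc(OC(F)(F)F)c(Cl)c1` with 33%, a gap beyond the scatter. Compound 4 `Cc1cc(Br)ccc1NC(=O)CN1CCC(c2cccc[n+]2[O-])CC1` awaits measurement and differs from compound 1 in one place: 4-bromo-2-methylphenyl in place of 3-chlorophenyl on an amide-type nitrogen. Going by the values given here, the only measured step that alters the same ring on the amide-type nitrogen is a number 1 percentage points lower from compound 1 to compound 3 (within the scatter), a change within the scatter, so this ring appears tolerant of variation. On that basis no shift beyond the scatter is expected, and the estimated step is a number 6 percentage points lower from compound 1 to compound 4 (within the scatter). The estimate for compound 4 in this assay is 70%, within 45% to 90%.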

Compound 4, largest response reached (reported as efficacy), in percent of the reference or control that the assay uses: 61%
The estimate for compound 4 lay 9 percentage points above the measured number, within the range that was stated.
By their numbers in this assay, from the lowest: compound 2; then compound 4; then compounds 3 and 1 (each within the scatter of the next).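

In this assay, the change on the amide-type nitrogen gives a number 15 percentage points lower from compound 1 to compound 4 (beyond the scatter), the only step shown at this position that passes the scatter; the ring there therefore does not accept every variation. The change removes the chloro group and brings in both a bromo and a methyl group, and the step alone does not tell which of these matters. Nothing available accounts for the lower number.

On these data alone, it remains open how a ring carrying only the bromo group or only the methyl group would read, and how an amine or a carboxylic acid on this ring would compare.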